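A few compounds are considered here, and "the series" means these few. Any claim that something is new, unique, unknown or untested is made for them only; others in the source may bear on it.

Of the compounds shown here, two have numbers so far in an assay on CHO cells for displacement of a labelled ligand from Alpha-2C adrenergic receptor (Homo sapiens); on this read-out higher numbers stand for weaker inhibition and lower numbers for stronger inhibition. Compound 1 `CC(Oc1ccccc1-c1cccnc1)C1=NCCN1` gives 64.6 nM. Compound 2 `CC(Oc1ccccc1-c1ccccc1)C1=NCCO1` gives 5890 nM, the higher of the two numbers, and the gap to compound 1 lies well beyond the scatter of repeated measurements. Compound 3 `CC(Oc1ccccc1-c1ccccc1)C1=NCCS1` has not yet been measured. It differs from compound 2 in one place: a group of 5 heavy atoms (3 carbon, 1 nitrogen, 1 sulfur; one five-membered non-aromatic ring with 2 hetero atoms) in place of a group of 5 heavy atoms (3 carbon, 1 nitrogen, 1 oxygen; one five-membered non-aromatic ring with 2 hetero atoms), on a saturated chain carbon bound to an oxygen on an aromatic ring and a saturated chain carbon. For the measured compounds named here, no measured pair of compounds shows this change on its own, so the size of its effect cannot be read from the numbers in hand. Both groups bring one five-membered non-aromatic ring with 2 hetero atoms and the same counts of heavy atoms and hydrogen-bond acceptors, and a small step, if any, is expected, in either direction and close to the scatter. On that basis compound 3 is expected to give about 3500 nM in this assay, with a range from 900 nM to 14000 nM. The expected step from compound 2 to compound 3 is a 1.7-fold lower number from compound 2 to compound 3 (0.23 log units; within the scatter).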

Compound 3, inhibition constant: < 10000 nM
Compound 3 ended at the assay's limit; the forecaster's own chance of this, stated with the estimate: 5%; the middle value lies beyond the limit too.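

Compound 3 gave a limit of the assay rather than a number, so no step from compound 2 to compound 3 can be read, because its value sits at: the limit of < 10000 nM in this assay, at which 1 of the 3 values shown sits.

The compounds shown leave open whether sulfur in place of oxygen in the five-membered non-aromatic ring changes the number at all, and in which direction.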